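The source may report more compounds than this note shows. Statements on the series, on what has been measured and on what is new or still open speak of the compounds shown alone.

Compound 3 `COc1cc(O)cc(O)c1C(=O)/C=C/c1ccccc1F` gives 16000 nM in a toxicity assay on cells (Macrophage, Mus musculus, strain BALB/c) for cytotoxicity, read by MTT assay; on this read-out lower numbers stand for stronger inhibition and higher numbers for weaker inhibition. Among the three measured compounds it shows the lowest number, though its nearest neighbour, compound 1 `COc1cc(O)cc(O)c1C(=O)/C=C/c1ccc(F)cc1`, gives 28800 nM in this assay and that gap lies within the scatter; the furthest is compound 2 `COc1cc(O)cc(O)c1C(=O)/C=C/c1ccco1`, which gives 384000 nM in this assay. The step of a 1.8-fold lower number from compound 1 to compound 3 (0.26 log units; within the scatter) swaps one fluorophenyl for another and stays within the scatter, whereas the steps of a 13-fold higher number from compound 1 to compound 2 (1.12 log units; beyond the scatter) and a 24-fold lower number from compound 2 to compound 3 (1.38 log units; beyond the scatter) are both large and both involve the furan-2-yl group.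

Compound 4 `COc1cc(O)cc(O)c1C(=O)/C=C/c1ccc(C)cc1` has not yet been measured. Its change from compound 3 is 4-methylphenyl in place of 2-fluorophenyl on a double-bonded chain carbon bound to a double-bonded chain carbon. Going by the values given here, no measured step in this set exchanges a fluorophenyl for a methylphenyl, so the nearest guide is the step of a 1.8-fold lower number from compound 1 to compound 3 (0.26 log units; within the scatter), where one substituted phenyl replaced another and the number moved only within the scatter. The large steps belong to compound 2 with its furan-2-yl group and do not apply here. Compound 4 is therefore expected to give a number close to that of compound 3, with a step of a 1.4-fold higher number from compound 3 to compound 4 (0.14 log units; within the scatter) that is not expected to go beyond the scatter in either direction. The estimate for compound 4 in this assay is 22000 nM, with a range from 8000 nM to 60000 nM.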

Compound 4, half-maximal inhibitory concentration: 16500 nM
The estimate for compound 4 lay 1.3-fold (0.12 log units) above the measured number; the measured number falls inside the stated range.
By their numbers in this assay, from the lowest: compounds 3, 4 and 1 (each within the scatter of the next); then compound 2.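

In this assay, a 4-methylphenyl group on a double-bonded chain carbon bound to a double-bonded chain carbon stays within the scatter of both fluorophenyl groups, with a 1.0-fold higher number from compound 3 to compound 4 (0.01 log units; within the scatter) and a 1.7-fold lower number from compound 1 to compound 4 (0.24 log units; within the scatter), the latter being methyl in place of fluoro on an aromatic carbon. The earlier compounds could set only fluorine-bearing phenyl groups against the furan-2-yl group, but a 23-fold lower number from compound 2 to compound 4 (1.37 log units; beyond the scatter) shows that the large gap also holds for a phenyl group without fluorine, so among these four compounds, fluorine on the ring is not needed for the separation from compound 2. Nothing shown here gives a reason for the close agreement among the three phenyl compounds or for their distance from compound 2.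

On these data alone, it remains open whether this tolerance extends to a phenyl group carrying an amine, a carboxylic acid or a longer chain, since only fluoro and methyl appear on the ring here. With compound 2 as the only compound without a phenyl group, the compounds shown also cannot tell whether its large gap is particular to the furan-2-yl group or would appear with other groups that replace the phenyl ring.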